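Small alkyl changes on a shared core: an estimate

The compounds below may be only part of what the source reports. "The series", "measured", "known", "first", "only" and "open" are said of these compounds alone.

In a functional assay on the whole organism (Cricetulus griseus) with Cricetinae gen. sp. as the target (a lower number here means that less compound is needed, a higher number that more compound is needed for the effect), the three measured compounds give:
compound 1 `COc1cccc(-c2n[nH]c(-c3ccccc3C)n2)c1`: 5 mg/kg
compound 2 `CCOc1cccc(-c2n[nH]c(-c3ccccc3C)n2)c1`: 5 mg/kg
compound 3 `C=CCOc1cccc(-c2nc(-c3ccccc3C)n[nH]2)c1`: 5 mg/kg

Compound 2 differs from compound 1 by methyl in place of hydrogen on a saturated chain carbon bound to an oxygen on an aromatic ring, and that step is no change at the digits printed from compound 1 to compound 2 (within the scatter). The difference between the core of compound 1 and the core of compound 3 is not broken down here; compound 3 sits level with compound 1 and compound 2. Compound 4, `C=CCOc1cccc(-c2nc(-c3ccccc3CC)n[nH]2)c1`, is not yet measured and differs from compound 3 by methyl in place of hydrogen on a saturated chain carbon bound to an aromatic carbon. Among the measured compounds shown here, this is the same kind of change as the one from compound 1 to compound 2, though there the saturated chain carbon is bound to an oxygen on an aromatic ring, while here it is bound to an aromatic carbon. A step of no change at the digits printed from compound 3 to compound 4 (within the scatter) is expected because no change at the digits printed from compound 1 to compound 2 (within the scatter) stayed flat for the same kind of change. In this assay compound 4 is therefore estimated at 5 mg/kg.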

Compound 4, dose for half-maximal effect: 5 mg/kg
Compound 4: middle estimate and measured number agree at the digits printed; the measured number falls inside the stated range.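

In this assay the new step reads no change at the digits printed from compound 3 to compound 4 (within the scatter), and set beside the earlier step on the other core it gives the same result: the same change on two cores in this assay, no change at the digits printed (within the scatter) from compound 1 to compound 2 and no change at the digits printed (within the scatter) from compound 3 to compound 4, 1.0-fold (0.00 log units) apart, within the scatter of two such steps. In these four compounds, then, the change carries from one core to the other without a visible step. This does not show that it would carry to other cores, and the two steps are not at an identical place: one is on a saturated chain carbon bound to an oxygen on an aromatic ring, the other on a saturated chain carbon bound to an aromatic carbon.

The compounds shown leave open whether a longer chain, an amine or a carboxylic acid at these places would stay level in this assay.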